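Bromo for trifluoromethyl on the pyridine ether series

A few compounds are considered here, and "the series" means these few. Any claim that something is new, unique, unknown or untested is made for them only; others in the source may bear on it.

Two compounds of this series have numbers in an assay on CHO-K1 cells for displacement of a labelled ligand from Neuronal acetylcholine receptor; alpha4/beta2 (Homo sapiens), read by scintillation counting; on this read-out higher numbers stand for weaker inhibition and lower numbers for stronger inhibition. Compound 1 `CN1[C@H](COc2cccnc2F)C[C@H]2C[C@H]21` carries an N-methyl group on the shared core and a fluoro substituent on the aromatic ring; in this assay compound 1 gives 31.9 nM. Compound 2 `FC(F)(F)c1ccc(OC[C@@H]2C[C@H]3C[C@H]3N2)cn1` has the unsubstituted amine of the shared core and a trifluoromethyl group on the aromatic ring; in this assay compound 2 gives 768 nM. Compound 2 thus stands at the higher of the two numbers, and the gap to compound 1 is well beyond the scatter; the two compounds differ in more than one place, so what the gap tells about any single change is not settled.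

Compound 3 `Brc1ccc(OC[C@@H]2C[C@H]3C[C@H]3N2)cn1` is not yet measured. It differs from compound 2 in one place: bromo in place of trifluoromethyl on an aromatic carbon. Among the compounds with values here, there is no measured pair that isolates this exchange. Within the data shown here, the expectation is a step from compound 2 to compound 3 of a 3.8-fold lower number from compound 2 to compound 3 (0.58 log units; beyond the scatter), a moderate move toward stronger inhibition, since the smaller single-atom substituent has no precedent here to anchor it more firmly. For compound 3 the estimated value in this assay is 200 nM, with a range from 50 nM to 800 nM.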

Compound 3, inhibition constant: 46.5 nM
Compound 3: middle estimate off by 4.3-fold (0.63 log units), on the high side, outside the stated range (below it).
By their numbers in this assay, from the lowest: compounds 1 and 3 (each within the scatter of the next); then compound 2.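

Within the data shown here, on the aromatic carbon next to the ring nitrogen, bromo in place of trifluoromethyl gives a 17-fold lower number from compound 2 to compound 3 (1.22 log units; beyond the scatter) in this assay, and this is the first pair that isolates a single change. The gap between the two earlier compounds could not be assigned to any one place, whereas this step shows that a change at this position alone, with the rest of compound 2 kept, moves the number well beyond the scatter, toward stronger inhibition. Four heavy atoms leave and one enters, with no hydrogen-bond donor or acceptor on either side, and nothing measured here accounts for the size of the step.

With only one exchange at this carbon, the compounds shown do not tell whether the step follows from losing trifluoromethyl, from gaining bromo, or from both, and chloro, methyl or nitrile at the same carbon would be needed to separate these readings. On these data alone, it also stays open whether the same exchange would give a step of similar size on the N-methyl form of the shared core, as only the unsubstituted amine carries this pair.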